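A few compounds are considered here, and "the series" means these few. Any claim that something is new, unique, unknown or untested is made for them only; others in the source may bear on it.

Measured in an ADME assay on microsomes from liver (Homo sapiens) for metabolic stability; on this read-out higher numbers stand for fast clearance and lower numbers for slow clearance:
compound 1 `O=C(Nc1ccnnc1)c1cc(N2CCCC2)ccc1OCc1ccccc1` gives 9.8 mL.min-1.g-1
compound 2 `CN1CCN(c2ccc(OCc3ccccc3)c(C(=O)Nc3ccnnc3)c2)CC1` gives 1.6 mL.min-1.g-1

Of the two, compound 2 holds the lower number at 1.6 mL.min-1.g-1. Going by the values given here, the only measured step is a 6.1-fold lower number from compound 1 to compound 2 (0.79 log units; beyond the scatter), modest in size and beyond the scatter. It exchanges pyrrolidin-1-yl for 4-methylpiperazin-1-yl on an aromatic carbon.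

Compound 3 `O=C(Nc1ccnnc1)c1cc(N2CCC(CO)CC2)ccc1OCc1ccccc1` changes the same place, meta to a (pyridazin-4-yl)carbamoyl group and para to a benzyloxy group. The change is 4-(hydroxymethyl)piperidin-1-yl in place of 4-methylpiperazin-1-yl (4-(hydroxymethyl)piperidin-1-yl in place of 4-methylpiperazin-1-yl on an aromatic carbon). Among the compounds with values here, the step from compound 1 is the only guide, and no measured compound carries 4-(hydroxymethyl)piperidin-1-yl, so the direction is uncertain.

Within the data shown here, with only two values, and compound 2 the lower, a partial move back toward compound 1 at 9.8 mL.min-1.g-1 is expected in this assay. The expected step is a 2.2-fold higher number from compound 2 to compound 3 (0.34 log units; beyond the scatter), a higher number but a smaller step than the measured one. For compound 3 the estimate is 3.5 mL.min-1.g-1, with an expected range from 1.4 mL.min-1.g-1 to 9 mL.min-1.g-1.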

Compound 3, intrinsic clearance in microsomes: 1 mL.min-1.g-1
Estimate against measurement, compound 3: 3.5-fold (0.54 log units) above; measured number outside the range, below it.
By their numbers in this assay, from the lowest: compounds 3 and 2 (each within the scatter of the next); then compound 1.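

In this assay, 4-(hydroxymethyl)piperidin-1-yl in place of 4-methylpiperazin-1-yl, at the position meta to a (pyridazin-4-yl)carbamoyl group and para to a benzyloxy group, gives a 1.6-fold lower number from compound 2 to compound 3 (0.20 log units; within the scatter) and so leaves the two six-membered groups unseparated on this read-out. The low clearance number therefore does not depend on 4-methylpiperazin-1-yl specifically, since a group with one hetero atom in the ring and a hydrogen-bond donor on its side chain sits in the same range. The contrast with the five-membered group also holds for this second six-membered group, with a 9.8-fold lower number from compound 1 to compound 3 (0.99 log units; beyond the scatter) as the step on the same core, and no supporting data on the cause of either step are available here.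

Pyrrolidin-1-yl differs from both six-membered groups in ring size and also in lacking a substituent, so the compounds shown leave open which of these two differences goes with the lower numbers. Plain piperidin-1-yl, or 3-(hydroxymethyl)pyrrolidin-1-yl, on the same core would separate the two, and morpholin-4-yl would extend the comparison to an oxygen in the ring.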